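Swapping the methoxyphenyl on a methylated core

The compounds below may be only part of what the source reports. "The series", "measured", "known", "first", "only" and "open" are said of these compounds alone.

In a functional assay on HepG2 cells (Homo sapiens) for cytotoxicity, read by MTT assay, with a stated time of 72 h (a higher number here means a weaker inhibitor, a lower number a stronger inhibitor), compound 1 `COc1ccc(-n2ccc(=O)c(C(=O)Nc3ccc(Oc4ccnc5[nH]ccc45)c(F)c3)n2)cc1` gives only a limit, > 60000 nM. Compound 2 `O=C(Nc1ccc(Oc2ccnc3[nH]ccc23)c(F)c1)c1nn(-c2ccc(Cl)c(F)c2)ccc1=O` gives 9610 nM in this assay. Compound 3 `COc1ccc(-n2ccc(=O)c(C(=O)Nc3ccc(Oc4ccnc5c4ccn5C)c(F)c3)n2)cc1`, which carries a methyl in place of hydrogen on an aromatic nitrogen of the shared core, likewise gives only a limit, > 60000 nM. Compound 3 therefore stands at the edge of what this assay reports, a position it shares with one other compound (the limit of > 60000 nM in this assay, at which 2 of the 3 values shown sit). For that reason the step that the two limits leave unreadable from compound 1 to compound 3 cannot be read in either direction.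

Compound 4 `Cn1ccc2c(Oc3ccc(NC(=O)c4nn(-c5ccc(Cl)c(F)c5)ccc4=O)cc3F)ccnc21` has not yet been measured. It differs from compound 3 in one place: 4-chloro-3-fluorophenyl in place of 4-methoxyphenyl on an aromatic nitrogen. The same exchange has been measured once before in this assay, and there it gave an at least 6.2-fold lower number from compound 1 to compound 2 (0.79 log units; beyond the scatter). For the measured compounds named here, that is the only measured step bearing on the new one. Because compound 3 sits at a limit, the true size of the coming step cannot be fixed, but a drop of comparable size is expected, amounting to an at least 5.0-fold lower number from compound 3 to compound 4 (0.69 log units; beyond the scatter). Compound 4 is estimated to give 12000 nM in this assay, with a plausible range from 3000 nM to 60000 nM.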

Compound 4, half-maximal inhibitory concentration: 22100 nM
Beside the measured number, compound 4's estimate is 1.8-fold (0.27 log units) below it; the range from low to high includes it.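

On the core that carries the methyl, 4-chloro-3-fluorophenyl in place of 4-methoxyphenyl gives an at least 2.7-fold lower number from compound 3 to compound 4 (0.43 log units; beyond the scatter), so a real drop now appears on this core as well, where compound 3 alone gave no measured number to work from. For the compounds shown here, the methyl on the aromatic nitrogen of the shared core can also be read for the first time, as a 2.3-fold higher number from compound 2 to compound 4 (0.36 log units; beyond the scatter), which in this assay means a weaker inhibitor with the methyl present when 4-chloro-3-fluorophenyl is the group in place. The exchange of the aryl group therefore moves the number the same way on both cores, though its size on each cannot be pinned down: the same change on two cores in this assay, an at least 6.2-fold lower number (0.79 log units; beyond the scatter) from compound 1 to compound 2 and an at least 2.7-fold lower number (0.43 log units; beyond the scatter) from compound 3 to compound 4; the limit leaves it open whether they differ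

On these data alone, the methyl step with 4-methoxyphenyl in place remains unreadable, and whether it matches the step seen with 4-chloro-3-fluorophenyl stays unknown: the limit of > 60000 nM in this assay, at which 2 of the 4 values shown sit. Also open is whether the chlorine, the fluorine or the two together account for the drop, a question that a 4-chlorophenyl or a 3-fluorophenyl group at this position would help to separate.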